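Thiosemicarbazones on a shared core: aromatic substituent variation

The source may hold more compounds than are shown below. What is called first, only, known or untested is meant among the compounds shown, and "the series" means these compounds.

The series holds compound 1 `CC1=CC[C@H](C(C)(C)NC(=S)N/N=C/c2ccccc2)CC1` and compound 2 `CC1=CC[C@H](C(C)(C)NC(=S)N/N=C/c2cccc(Cl)c2)CC1`, measured in a functional assay on 786-0 cells (Homo sapiens) for inhibition, read by sulforhodamine B assay, with a stated time of 48 h; a lower number here means a stronger inhibitor of growth, a higher number a weaker inhibitor of growth. Compound 1 gives 9900 nM and compound 2 gives 9200 nM; the two numbers lie within the scatter of each other, and compound 2 stands nowhere apart from compound 1 in this assay. Going by the values given here, the only step so far, a 1.1-fold lower number from compound 1 to compound 2 (0.03 log units; within the scatter), shows that exchanging a substituent on the aromatic carbon left the number unchanged beyond the scatter. Compound 3 `CC1=CC[C@H](C(C)(C)NC(=S)N/N=C/c2cccc([N+](=O)[O-])c2)CC1` is not yet measured; it differs from compound 2 by nitro in place of chloro on an aromatic carbon. Among the compounds with values here, the one step that bears on this change is a 1.1-fold lower number from compound 1 to compound 2 (0.03 log units; within the scatter), and it was within the scatter, so for compound 3 no step beyond the scatter is expected in either direction, an estimated 1.0-fold lower number from compound 2 to compound 3 (0.01 log units; within the scatter). Compound 3 is thus expected near 9000 nM, with a range of 4000 nM to 20000 nM in this assay.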

Compound 3, concentration for 50% growth inhibition: > 100000 nM
Compound 3 gave a limit, no number (the forecaster's own chance of this, stated with the estimate: 10%); middle value at least 11-fold (1.04 log units) from the limit.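

Compound 3 gives a limit, not a number, in this assay: the limit of > 100000 nM in this assay, at which 1 of the 3 values shown sits. The place meta to a large group is therefore not indifferent to what it carries: nitro brings an at least 10-fold higher number from compound 2 to compound 3 (1.03 log units; beyond the scatter) and an at least 10-fold higher number from compound 1 to compound 3 (1.00 log units; beyond the scatter). The flat picture from a 1.1-fold lower number from compound 1 to compound 2 (0.03 log units; within the scatter) thus holds for chloro and hydrogen only, not for every group at this place on the shared core.

The compounds shown do not say why nitro differs from chloro here, and with a single nitro compound the change cannot be tied to any one feature of that group. On these data alone, whether an amine, a nitrile or a methoxy group at this place would follow chloro or nitro remains open, as does the effect of nitro elsewhere on the aromatic ring.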